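A few compounds are considered here, and "the series" means these few. Any claim that something is new, unique, unknown or untested is made for them only; others in the source may bear on it.

Measured so far:
compound 1 `Cn1nc(-c2ccnc(Nc3ccc([N+](=O)[O-])cc3)n2)c2ccccc21` gives 8220 nM in a functional assay on HCT-116 cells (Homo sapiens) for antiproliferative activity, read by MTT assay, with a stated time of 72 h; on this read-out lower numbers stand for stronger inhibition of growth and higher numbers for weaker inhibition of growth
compound 2 `CCn1nc(-c2ccnc(Nc3ccc(S(N)(=O)=O)cc3)n2)c2ccccc21` gives 2050 nM in this assay

Compound 2 holds the lower of the two numbers; compound 1 sits higher by a margin beyond the usual scatter. Compound 3 `CCn1nc(-c2ccnc(Nc3ccc([N+](=O)[O-])cc3)n2)c2ccccc21` is reached from compound 2 by nitro in place of sulfamoyl on an aromatic carbon. Within the data shown here, no step between measured compounds covers this change on its own. Compound 1 also carries the nitro group and gives 8220 nM in this assay. On that basis the change is expected to raise the number, by a step of a 2.9-fold higher number from compound 2 to compound 3 (0.47 log units; beyond the scatter). Compound 3 is therefore estimated at 6000 nM, with a range from 2500 nM to 15000 nM.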

Compound 3, concentration for 50% growth inhibition: 4060 nM
Compound 3: the middle estimate sits 1.5-fold (0.17 log units) above what was measured; measured number inside the range.
By their numbers in this assay, from the lowest: compounds 2 and 3 (each within the scatter of the next); then compound 1.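

In this assay, nitro in place of sulfamoyl on the aromatic carbon para to a large group gives a 2.0-fold higher number from compound 2 to compound 3 (0.30 log units; within the scatter) and so does not separate the two groups on this core. With nitro held, methyl in place of hydrogen on the saturated chain carbon bound to an aromatic nitrogen gives a 2.0-fold lower number from compound 1 to compound 3 (0.31 log units; beyond the scatter) as a modest first reading on the chain. No measurement at hand accounts for either step. Open, going by these compounds, is whether an amine or a carboxylic acid at that aromatic carbon would hold the number, and whether a longer chain on the aromatic nitrogen would continue the step.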